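A Methoxy on the Fused Ring of Compound 2

The compounds below may be only part of what the source reports. "The series", "measured", "known", "first", "only" and "open" are said of these compounds alone.

Of the compounds shown here, three sharing one core have been measured in a functional assay on MCF7 cells (Homo sapiens) for cytotoxicity, read by sulforhodamine B assay, with a stated time of 48 h; on this read-out higher numbers stand for weaker inhibition of growth and lower numbers for stronger inhibition of growth. Compound 1 `Cc1ccc(-c2ccc(C)n2-c2ccc(-c3nc4ccccc4s3)cc2)cc1` gives 2500 nM, compound 2 `COc1cc(-c2ccc(C)n2-c2ccc(-c3nc4ccccc4s3)cc2)cc(OC)c1OC` gives 2340 nM, and compound 3 `Cc1ccc(-c2ccc(F)cc2)n1-c1ccc(-c2nc3ccc(F)cc3s2)cc1` gives 1790 nM. Compound 2 holds the second highest of the three numbers; its nearest neighbour is compound 1, whose number lies within the scatter of its own, and compound 3, the furthest from it, also differs from compound 2 by an amount within the scatter. On these figures the three compounds cannot be told apart.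

Compound 4 `COc1ccc2nc(-c3ccc(-n4c(C)ccc4-c4cc(OC)c(OC)c(OC)c4)cc3)sc2c1` has not yet been measured in this assay. It differs from compound 2 in one place: methoxy in place of hydrogen on an aromatic carbon. Within the data shown here, no measured pair in this set shows the effect of such a change on its own, so the numbers say nothing direct about it. What they do show is that compound 1 and compound 3, which differ at several places, give numbers within the scatter of each other, and that the whole set spans a narrow range. The expected step, a 1.2-fold lower number from compound 2 to compound 4 (0.07 log units; within the scatter), is therefore small and in no direction beyond the scatter. Compound 4 is estimated to give 2000 nM in this assay, within a range from 800 nM to 5000 nM.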

Compound 4, concentration for 50% growth inhibition: 920 nM
Estimate against measurement, compound 4: 2.2-fold (0.34 log units) above; the measured number falls inside the stated range.
By their numbers in this assay, from the lowest: compounds 4, 3, 2 and 1 (each within the scatter of the next, the first and the last beyond it).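

In this assay, among these compounds, the change from 1,3-benzothiazol-2-yl to 6-methoxy-1,3-benzothiazol-2-yl gives a 2.5-fold lower number from compound 2 to compound 4 (0.41 log units; beyond the scatter) and is the first single change in this set whose size can be read, since the earlier compounds shared no one-place step and their numbers could not be told apart. It shows that this aromatic carbon, on the six-membered ring of carbon only within the fused system, is a place where one added methoxy can move the number beyond the scatter toward stronger inhibition of growth, though the step is modest and rests on this one pair. Nothing among the data shown accounts for the step.

As far as these compounds go, whether the step belongs to methoxy itself or would also appear with another group on the same carbon, such as a hydroxyl, an ethoxy or an amine, remains open. Also open, from the compounds shown here alone, is whether methoxy at this place would bring a similar step on the core of compound 1, which has a different aromatic ring on the other side of the molecule from compound 2.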